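Changing the aryl group on the ring nitrogen

The source may hold more compounds than are shown below. What is called first, only, known or untested is meant among the compounds shown, and "the series" means these compounds.

Compound 3 `COc1ccc(-n2nncc2CN2C(=O)C3(C(C#N)=C(N)Oc4c(N)cc5nc6ccccc6nc5c43)c3ccccc32)cc1` carries a 4-methoxyphenyl group on an aromatic nitrogen of a five-membered aromatic ring with 3 nitrogen. In a functional assay on HepG2 cells (Homo sapiens) for antiproliferative activity, read by MTT assay, with a stated time of 48 h (on this read-out lower numbers stand for stronger inhibition and higher numbers for weaker inhibition), compound 3 gives only a limit, > 50000 nM, so its strength is not fixed to a number. Two companions share the same core. Compound 1 `Cc1ccccc1-n1nncc1CN1C(=O)C2(C(C#N)=C(N)Oc3c(N)cc4nc5ccccc5nc4c32)c2ccccc21` bears a 2-methylphenyl group at that nitrogen, and in this assay compound 1 also stops at a limit, > 50000 nM. Going by the values given here, compound 2 `N#CC1=C(N)Oc2c(N)cc3nc4ccccc4nc3c2C12C(=O)N(Cc1cnnn1-c1cccc(C(F)(F)F)c1)c1ccccc12` bears a 3-(trifluoromethyl)phenyl group, and in this assay compound 2 gives 15800 nM, the only measured number of the three. The step of an at least 3.1-fold lower number from compound 1 to compound 2 (0.50 log units; beyond the scatter) and the step of an at least 3.1-fold higher number from compound 2 to compound 3 (0.50 log units; beyond the scatter) set the trifluoromethyl compound apart, whereas the step that the two limits leave unreadable from compound 1 to compound 3 cannot be sized because the limit of > 50000 nM in this assay, at which 2 of the 3 values shown sit, caps both ends.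

Compound 4 `Cc1ccc(C)c(-n2nncc2CN2C(=O)C3(C(C#N)=C(N)Oc4c(N)cc5nc6ccccc6nc5c43)c3ccccc32)c1` is not yet measured. Its change: 2,5-dimethylphenyl in place of 4-methoxyphenyl on an aromatic nitrogen. The two aryl groups carrying methyl or methoxy, in compound 1 and compound 3, both ended at the limit, and only the trifluoromethyl group in compound 2 gave a readable number. A dimethylphenyl group therefore is expected to behave like those two. Compound 4 is expected to give about 50000 nM, between 20000 nM and 120000 nM. The step of a number no higher from compound 3 to compound 4 (the limit leaves the size open) is thus estimated to stay within the scatter.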

Compound 4, half-maximal inhibitory concentration: > 50000 nM
Compound 4: no number, only a limit; the forecaster's own chance of this, stated with the estimate: 65%; the middle value lies on the limit itself.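

With 2,5-dimethylphenyl, a third aryl group ends at a limit rather than a number, so compound 2 remains the only one of the four with a measured value in this assay. Going by these compounds alone, the step of an at least 3.1-fold higher number from compound 2 to compound 4 (0.50 log units; beyond the scatter) extends to a ring with two methyl groups what the earlier compounds showed for a ring with one methyl group and for one with a methoxy group. The steps among compound 1, compound 3 and compound 4 cannot be read, so these three cannot be placed in any order, and adding the second methyl group has no readable effect, because all three values are capped in the same way: the limit of > 50000 nM in this assay, at which 3 of the 4 values shown sit.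

It remains open whether the readable value of compound 2 depends on the trifluoromethyl group itself or on where that group sits on the phenyl ring, since no other compound shown carries it. A 4-(trifluoromethyl)phenyl, 3-chlorophenyl or 3-aminophenyl group at this nitrogen would help to separate these possibilities, and none of them is among the compounds shown.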